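Dimethylamino versus methylamino on the shared pyrimidine-styryl series

The source may report more compounds than this note shows. Statements on the series, on what has been measured and on what is new or still open speak of the compounds shown alone.

Measured so far:
Compound 1 `CN(C)c1ncc(/C=C/c2c(F)cccc2F)cn1`: > 200 nM
Compound 2 `CNc1ncc(/C=C/c2c(F)cccc2F)cn1`: > 200 nM
Compound 3 `CN(C)c1ncc(/C=C/c2c(Cl)cccc2Cl)cn1`: > 200 nM

In a functional assay on LS174T cells (Homo sapiens) for antiproliferative activity (a higher number here means a weaker inhibitor, a lower number a stronger inhibitor), compound 1 gives only a limit, > 200 nM. Compound 2 likewise gives only a limit, > 200 nM. Compound 3 gives only a limit, > 200 nM. The change from compound 1 to compound 2 is hydrogen in place of methyl on a nitrogen on an aromatic ring; the step it made, a step that the two limits leave unreadable from compound 1 to compound 2, cannot be read. The difference between the cores of compound 1 and compound 3 is not broken down here. Compound 4 `CNc1ncc(/C=C/c2c(Cl)cccc2Cl)cn1` is not yet measured; it carries the same change as before, (hydrogen in place of methyl on a nitrogen on an aromatic ring), now on the core of compound 3. The step from compound 3 to compound 4 is expected to be a step that the limit leaves unreadable from compound 3 to compound 4 because the limit of > 200 nM in this assay, at which 3 of the 3 values shown sit, is where every value stands. Compound 4 is therefore estimated at 400 nM, most likely again only a limit.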

Compound 4, half-maximal inhibitory concentration: > 200 nM
Compound 4 was reported as a limit; the forecaster's own chance of this, stated with the estimate: 75%; the middle value is on the limit's open side.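

No step can be read from compound 3 to compound 4 because both values are limits: the limit of > 200 nM in this assay, at which 4 of the 4 values shown sit.

The compounds shown leave open what size, if any, the change from dimethylamino to methylamino has on either core.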